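Methyl on the oxygen of compound 3

A few compounds are considered here, and "the series" means these few. Any claim that something is new, unique, unknown or untested is made for them only; others in the source may bear on it.

In a functional assay on SGC-7901 cells (Homo sapiens) for antiproliferative activity, read by MTT assay, with a stated time of 72 h (a higher number here means a weaker inhibitor, a lower number a stronger inhibitor), compound 1 (`COc1ccc(-c2ssc(=S)c2-c2cc(OC)c(OC)c(OC)c2)cc1`) gives 21100 nM as its reading. Compound 2 (`COc1ccc(-c2c(-c3cc(OC)c(OC)c(OC)c3)ss/c2=N/O)cc1`) gives > 100000 nM as its reading, which is a limit of the assay and not a number. Compound 3 (`COc1ccc(-c2c(-c3cc(OC)c(OC)c(OC)c3)ss/c2=N/O)cc1N`) gives 2910 nM as its reading and so holds the lower of the two true numbers, with a gap to compound 1 that lies beyond the scatter.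

Compound 4 (`CO/N=c1/ssc(-c2cc(OC)c(OC)c(OC)c2)c1-c1ccc(OC)c(N)c1`) has not yet been measured. It departs from compound 3 by methyl in place of hydrogen on an oxygen in a single place, methyl in place of hydrogen on an oxygen, or hydroxy to methoxy.

Within the data shown here, the one measured step sits elsewhere. Amino in place of hydrogen on an aromatic carbon gave an at least 34-fold lower number from compound 2 to compound 3 (1.53 log units; beyond the scatter) in this assay and that step is large, but it does not touch this oxygen. Among the measured compounds shown here, no measured pair changes hydroxy to methoxy, so the data favour no direction. The estimate therefore stays anchored on compound 3 at 2910 nM with a wide range. The expected outcome is a 1.0-fold higher number from compound 3 to compound 4 (0.01 log units; within the scatter) in this assay and no change beyond the scatter is expected. For compound 4 the estimated value is 3000 nM with an expected range of 700 nM to 13000 nM in this series.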

Compound 4, half-maximal inhibitory concentration: 1960 nM
Compound 4: middle estimate off by 1.5-fold (0.18 log units), on the high side; measured number inside the range.
By their numbers in this assay, from the lowest: compounds 4 and 3 (each within the scatter of the next); then compound 1. At a limit, above all of these: compound 2.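

In this assay, among these compounds, methyl in place of hydrogen on the oxygen whose other neighbour is the double-bonded nitrogen gives a 1.5-fold lower number from compound 3 to compound 4 (0.17 log units; within the scatter), the first reading of any change at this position. With the amino group kept, the hydrogen on this oxygen is therefore not needed to hold the reading of compound 3 in this assay, since hydroxy and methoxy here stand within the scatter of each other, and this oxygen accepts at least a methyl without a step beyond the scatter. Nothing measured here bears on a cause for this step.

Open, as far as these compounds go, is whether a longer chain on this oxygen, such as ethyl or benzyl, or a carboxylic acid carried on such a chain, stays within the scatter of compound 3 as methyl does. Also open, from the compounds shown here alone, is whether hydroxy to methoxy reads the same way on a core without the amino group, so this single pair cannot yet be taken as a rule for the series.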